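This account rests on a few compounds, and the source may have more. Where it says the series, first, only, none or still open, it means among the compounds named here.

In an ADME assay (liver) for metabolic stability, with Liver microsome (Homo sapiens) as the target, using microsomes and NADPH, with a stated time of 30 min, tested at 1 uM (a higher number here means faster removal of the compound, a lower number slower removal), compound 1 `Nc1ccc(S(=O)(=O)N2CCN(c3ncc(C(O)(C(F)(F)F)C(F)(F)F)cc3-c3cccc(F)c3)CC2)cn1` gives 25 mL.min-1.g-1 and compound 2 `COc1cncc(-c2cc(C(O)(C(F)(F)F)C(F)(F)F)cnc2N2CCN(S(=O)(=O)c3ccc(N)nc3)CC2)c1` gives 44 mL.min-1.g-1 on the shared core. For the measured compounds named here, compound 2 therefore stands within the scatter of compound 1, the only other number available. Compound 3 `Nc1ccc(S(=O)(=O)N2CCN(c3ncc(C(O)(C(F)(F)F)C(F)(F)F)cc3-c3ccc4scnc4c3)CC2)cn1` changes the same aromatic carbon, ortho to a large group, with 1,3-benzothiazol-5-yl in place of 5-methoxypyridin-3-yl on an aromatic carbon and nothing else altered. Going by the values given here, no measured compound carries 1,3-benzothiazol-5-yl. Among the compounds with values here, the single step that bears on this change is the one at that carbon between compound 1 and compound 2 a 1.8-fold higher number from compound 1 to compound 2 (0.25 log units; within the scatter) which stayed inside the scatter. On that thin evidence, no step beyond the scatter is expected in either direction. The expected step is a 1.3-fold lower number from compound 2 to compound 3 (0.10 log units; within the scatter) as an estimate only. Compound 3 is estimated in this assay at 35 mL.min-1.g-1 with an expected range from 15 mL.min-1.g-1 to 80 mL.min-1.g-1 for repeat measurements.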

Compound 3, intrinsic clearance in microsomes: 39 mL.min-1.g-1
Estimate against measurement, compound 3: 1.1-fold (0.05 log units) below; the range from low to high includes it.
By their numbers in this assay, from the lowest: compounds 1, 3 and 2 (each within the scatter of the next).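

In this assay, moving to 1,3-benzothiazol-5-yl, which brings a five-membered aromatic ring with 2 hetero atoms into this position, gives a 1.1-fold lower number from compound 2 to compound 3 (0.05 log units; within the scatter) and a 1.6-fold higher number from compound 1 to compound 3 (0.19 log units; within the scatter). The aromatic carbon ortho to a large group has now carried 3-fluorophenyl, 5-methoxypyridin-3-yl and 1,3-benzothiazol-5-yl, and every step among compound 1, compound 2 and compound 3 lies within the scatter, so swapping one of these aromatic groups for another at this carbon has produced no clear separation on the shared core. Nothing available explains this result.

Still open, from the compounds shown here alone, is whether a non-aromatic group at this carbon, such as an amine or a short alkyl chain, would give a step beyond the scatter. Equally open, going by these compounds, is whether a carboxylic acid in place of the 2,2,2-trifluoro-1-hydroxy-1-(trifluoromethyl)ethyl group would do so.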